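From compound 1 to compound 3: working notes

The compounds below may be only part of what the source reports. "The series", "measured", "known", "first", "only" and "open" are said of these compounds alone.

Measured in an ADME assay on L6 cells (Rattus norvegicus) for cytotoxicity; on this read-out lower numbers stand for stronger inhibition and higher numbers for weaker inhibition:
- compound 1 `CN(C)C12CC(OC(=O)CN3CCCCC3)C(C(c3ccccc3)C1)C(c1ccccc1)C2`: 29300 nM
- compound 2 `O=C(CN1CCCCC1)OC1CC2(N3CCCCC3)CC(c3ccccc3)C1C(c1ccccc1)C2`: 60400 nM; > 184000 nM (2 entries)

Within the data shown here, compound 1 is the only compound with a single number in this assay. Compound 2 has several entries (the several entries of compound 2 in this assay, 60400 nM; > 184000 nM (2 entries)), and those with the sign are limits of the assay, not numbers.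

Compound 3 `CN(C)C12CC(OC(=O)CCN3CCCCC3)C(C(c3ccccc3)C1)C(c1ccccc1)C2` has not been measured. It differs from compound 1 as follows: (piperidin-1-yl)methyl in place of piperidin-1-yl on a saturated chain carbon bound to a carbonyl carbon. Read one bond further out, (piperidin-1-yl)methyl becomes 2-(piperidin-1-yl)ethyl. Among the measured compounds shown here, no measured pair shows this change, so the expectation rests on compound 1 at 29300 nM. The expected 1.0-fold higher number from compound 1 to compound 3 (0.01 log units; within the scatter) is estimated to stay within the usual scatter, with no direction favoured. For compound 3 the expected value is 30000 nM, with an estimated range from 12000 nM to 75000 nM.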

Compound 3, half-maximal inhibitory concentration: 25800 nM
Compound 3: the middle estimate sits 1.2-fold (0.07 log units) above what was measured; low and high end bracket the measured number.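

In this assay the series now has its first readable step, a 1.1-fold lower number from compound 1 to compound 3 (0.06 log units; within the scatter) and so stays within the scatter. At this place, on a saturated chain carbon bound to a carbonyl carbon, (piperidin-1-yl)methyl thus reads the same as piperidin-1-yl on the core of compound 1, though this rests on a single pair. Nothing at hand bears on why the read-out holds across this change.

From the compounds shown here alone, what a longer chain such as 3-(piperidin-1-yl)propyl, or a morpholin-4-yl in place of the piperidin-1-yl, would give at this place remains open. Also open, going by these compounds, is whether the same change would read alike on the core of compound 2, where the piperidin-1-yl replaces the dimethylamino group of compound 1.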